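Methoxy for Methyl on the Anilino Ring

The compounds below may be only part of what the source reports. "The series", "measured", "known", "first", "only" and "open" are said of these compounds alone.

Compound 1 `COc1ccc(C(=O)c2sc(Nc3ccccc3)c(C(=O)O)c2C)cc1` provides the reference point: in a functional assay, with a stated time of 150 min, tested at 20 ug/mL (on this read-out lower numbers stand for a weaker effect and higher numbers for a stronger effect at the one concentration tested), compound 1 gives 41.2%. Compound 2 `COc1ccc(C(=O)c2sc(Nc3ccc(C)cc3)c(C(=O)O)c2C)cc1`, which carries a methyl on its anilino ring, was reported in this assay as "not active" (no number reported), so compound 2 stands without a single number, and nothing can be said about the size of its gap to compound 1 beyond noting that compound 1 did yield a figure while compound 2 did not. Compound 3 `COc1ccc(Nc2sc(C(=O)c3ccc(OC)cc3)c(C)c2C(=O)O)cc1` has not yet been tested in this assay. It differs from compound 2 in one place: methoxy in place of methyl on an aromatic carbon. For the measured compounds named here, no measured step between compounds shows how such a change plays out here, so the expectation rests on compound 2 alone. Because compound 2 gave "not active" (no number reported), any movement in this assay on going to compound 3 is expected to be small, within the scatter or a modest rise. Compound 3 is estimated to show 12%, with a range from 0% to 40%.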

Compound 3, a percentage reported as activity, at one concentration (the size of the read-out at that concentration, not a potency): 32.5%
Estimate against measurement, compound 3: 20.5 percentage points below; low and high end bracket the measured number.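

In this assay compound 3 gives 32.5% and so keeps a figure at the place where compound 2, with its methyl, was reported as "not active". Methoxy in place of hydrogen on this aromatic carbon, para to a large group, comes to a number 8.7 percentage points lower from compound 1 to compound 3 (within the scatter) and therefore leaves the read-out level with that of the unsubstituted anilino ring; a substituent here does not in itself abolish the effect, with compound 2 as the case that goes the other way. The step between compound 2 and compound 3 cannot be read as a size, and nothing at hand accounts for the contrast between methyl and methoxy.

From the compounds shown here alone, it remains open how other groups at this place would read, such as a chlorine atom, a hydroxyl or an amine. Whether a longer alkoxy chain would keep a figure as methoxy does also stays undecided.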